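The source may report more compounds than this note shows. Statements on the series, on what has been measured and on what is new or still open speak of the compounds shown alone.

Compound 1 `O=C(CCCCC1CCSS1)NO`: "not active" (no number reported)
Compound 2 `O=C(CCCCC1CCSS1)Nc1ccccn1`: 1.14%

Two compounds have been examined in a functional assay on HO8910 cells (Homo sapiens) for inhibition, read by MTT assay, with a stated time of 24 h, tested at 0.1 ug/mL; a lower number here means less inhibition of growth, a higher number more inhibition of growth at the concentration tested. Compound 1 was reported as "not active" (no number reported), with no number attached. Compound 2 gave 1.14%, which is the only numerical result so far and lies close to no inhibition at all. With a single number, compound 2 cannot be ranked on any measured scale.

The next compound to be tested is compound 3 `O=C(CCCCC1CCSS1)Nc1ccc(Cl)cn1`, which keeps the structure of compound 2 apart from one substitution: chloro in place of hydrogen on an aromatic carbon. Going by the values given here, the data contain no measured example of this change or of any other single change, so its effect in this assay can only be judged loosely. The expectation is for no step beyond the usual scatter, with any small shift more likely toward greater inhibition of growth, since compound 2 at 1.14% leaves little room for a fall. The expected change is a number 2.9 percentage points higher from compound 2 to compound 3 (within the scatter). For compound 3 the estimated value is 4%, with an expected range of 0% to 14%.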

Compound 3, percent growth inhibition at one concentration: "not active" (no number reported)
No number was reported for compound 3; no gap can be computed for the estimate.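

In this assay, going by these compounds alone, compound 3 gives "not active" (no number reported) and so offers no number to set against compound 2, which means no step from one to the other can be read. No measured evidence bears on this result. The compounds shown leave open what chloro in place of hydrogen does to growth inhibition in this series.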